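Swapping the Sulfonamide Heteroaryl: Oxazole to Pyrimidine

This account rests on a few compounds, and the source may have more. Where it says the series, first, only, none or still open, it means among the compounds named here.

Of the compounds shown here, three sharing one core have been measured in a functional assay on MDA-MB-231 cells (Homo sapiens) for antiproliferative activity, read by sulforhodamine B assay, with a stated time of 48 h; a lower number here means a stronger inhibitor, a higher number a weaker inhibitor. Compound 1 `Nc1ccc(S(=O)(=O)Nc2ccnc3cc(C(F)(F)F)ccc23)cc1` gives 31000 nM. Among the measured compounds shown here, compound 2 `O=C(Nc1ccccc1)Nc1ccc(S(=O)(=O)Nc2ccnc3cc(C(F)(F)F)ccc23)cc1` gives 52900 nM; the single known step, a 1.7-fold higher number from compound 1 to compound 2 (0.23 log units; within the scatter), changes only the amine end of the molecule. Compound 3 `Cc1cc(NS(=O)(=O)c2ccc(N/C(S)=N\c3ccnc4cc(C(F)(F)F)ccc34)cc2)on1` gives 80300 nM, the highest of the three numbers; it lies within the scatter of compound 2 but beyond the scatter of compound 1.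

Compound 4 `O=S(=O)(Nc1ncccn1)c1ccc(N/C(S)=N\c2ccnc3cc(C(F)(F)F)ccc23)cc1` differs from compound 3 in one place: pyrimidin-2-yl in place of 3-methyl-1,2-oxazol-5-yl on a sulfonamide nitrogen. For the measured compounds named here, no measured step touches this part of the molecule, and the one step that is known concerns a different nitrogen, so it gives no guide to the size or direction of this change. With nothing to point either way, the expectation for compound 4 is a number close to that of compound 3, a step of a 1.0-fold lower number from compound 3 to compound 4 (0.00 log units; within the scatter), not beyond the scatter. Compound 4 is therefore estimated at 80000 nM, with a range from 30000 nM to 200000 nM.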

Compound 4, half-maximal inhibitory concentration: 45200 nM
Estimate against measurement, compound 4: 1.8-fold (0.25 log units) above; low and high end bracket the measured number.
By their numbers in this assay, from the lowest: compounds 1, 4, 2 and 3 (each within the scatter of the next, the first and the last beyond it).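

Among the compounds shown here, this is the first view of the group on the sulfonamide nitrogen. In this assay, pyrimidin-2-yl in place of 3-methyl-1,2-oxazol-5-yl gives a 1.8-fold lower number from compound 3 to compound 4 (0.25 log units; within the scatter), so for this one pair, a six-membered aromatic ring with 2 hetero atoms and a five-membered one cannot be told apart in this read-out. No measurement is available that could explain this result.

Going by these compounds, what remains open is how much this position matters at all, since both groups are aromatic rings with 2 hetero atoms of the same heavy-atom count. A plain phenyl ring, a ring with a single hetero atom such as pyridin-2-yl, a small methyl group, or simply hydrogen on that nitrogen would test whether a larger change here moves the number beyond the scatter.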